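A few compounds are considered here, and "the series" means these few. Any claim that something is new, unique, unknown or untested is made for them only; others in the source may bear on it.

In a functional assay on OVCAR-4 cells (Homo sapiens) for inhibition, with a stated time of 48 h (a higher number here means a weaker inhibitor of growth, a lower number a stronger inhibitor of growth), compound 1 (`COc1ccccc1/C=C/C(=O)c1c(O)cc2occc2c1OC`) gives > 100000 nM as a limit of the assay and not a number. In this assay compound 2 (`COc1c(C(=O)/C=C/c2ccc(Cl)cc2)c(O)c(Br)c2occc12`) gives 3280 nM and compound 3 (`C=CCc1c(O)c(C(=O)/C=C/c2ccccc2)c(OC)c2ccoc12`) gives 2890 nM with the two values lying within the usual scatter of each other. Compound 3 therefore stands level with compound 2, and no order can be drawn between them.

Compound 4 (`C=CCc1c(O)c(C(=O)/C=C/c2ccc(Cl)cc2)c(OC)c2ccoc12`) is compound 3 with a single change (chloro in place of hydrogen on an aromatic carbon) in which chloro takes the place of hydrogen on an aromatic carbon, para to a large group, so that phenyl becomes 4-chlorophenyl. Among the measured compounds shown here, no two measured compounds differ in just one place, so no measured step shows what this change does. The nearest hint is indirect: compound 2 also carries a 4-chlorophenyl group and differs from compound 3 elsewhere, and in this assay compound 2 gives 3280 nM as its reading. On that basis, no step beyond the scatter is expected. The estimated change is a 1.2-fold lower number from compound 3 to compound 4 (0.06 log units; within the scatter) and nothing larger is expected. Estimated from these figures, compound 4 should read 2500 nM with 800 nM to 8000 nM as its likely range.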

Compound 4, concentration for 50% growth inhibition: 2770 nM
Compound 4: middle estimate off by 1.1-fold (0.04 log units), on the low side, within the range that was stated.
By their numbers in this assay, from the lowest: compounds 4, 3 and 2 (each within the scatter of the next). At a limit, above all of these: compound 1.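

In this assay, among the compounds shown here, the first direct reading of chloro in place of hydrogen on an aromatic carbon, para to a large group, is a 1.0-fold lower number from compound 3 to compound 4 (0.02 log units; within the scatter), so phenyl and 4-chlorophenyl cannot be told apart at this place. For the compounds shown here, compound 4 also gives a first one-place reading at a second site, where allyl in place of bromo on an aromatic carbon, with the 4-chlorophenyl group held the same, is a 1.2-fold lower number from compound 2 to compound 4 (0.07 log units; within the scatter), so these two groups cannot be told apart there either. The information at hand offers no reason why neither swap moves the reading beyond the scatter.

The compounds shown carry only hydrogen and chloro at the first place, and only bromo and allyl at the second, so it stays open what an amine or a carboxylic acid would do at the first, or a longer chain at the second. Going by these compounds alone, compound 1 reads > 100000 nM, a limit of the assay and not a number, and it differs from the other compounds in more than one place, so no step to it can be read.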